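Imidazolyl for pyrrolyl in the aminoimidazoline series

The compounds below may be only part of what the source reports. "The series", "measured", "known", "first", "only" and "open" are said of these compounds alone.

Compound 1 `Cn1cccc1-c1ccccc1NCC1=NCCN1` gives 0% in a functional assay with Alpha-1B adrenergic receptor (Homo sapiens) as the target, read by calcium flux; on this read-out lower numbers stand for smaller maximal responses and higher numbers for larger maximal responses. Compound 2 `CC(C)n1nccc1-c1ccccc1NCC1=NCCN1` gives 0%, and compound 3 `CCn1cccc1-c1ccccc1NCC1=NCCN1` gives 0%, so compound 1 stands level with both at the digits shown. Going by the values given here, the only recorded step, no change at the digits printed from compound 1 to compound 3 (within the scatter), concerns the saturated chain carbon bound to the aromatic nitrogen, not the five-membered ring, and so bears on the present change only as a sign of a flat series. Compound 4 `Cn1ccnc1-c1ccccc1NCC1=NCCN1` differs from compound 1 by 1-methyl-1H-imidazol-2-yl in place of 1-methyl-1H-pyrrol-2-yl on an aromatic carbon. Among the compounds with values here, no measured step touches this ring; compound 1 and compound 2, whose rings already differ in hetero atoms, show the same read-out. The estimated step is therefore none beyond the scatter, a number 1 percentage points higher from compound 1 to compound 4 (within the scatter). Compound 4 is expected at 1%, within 0% to 12%.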

Compound 4, largest response reached (reported as maximal response), in percent of the reference or control that the assay uses: 104%
Compound 4: middle estimate off by 103 percentage points, on the low side; measured number outside the range, above it.
By their numbers in this assay, from the lowest: compounds 1, 2 and 3 (each within the scatter of the next); then compound 4.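

In this assay, the ring on this aromatic carbon proves decisive: 1-methyl-1H-imidazol-2-yl in place of 1-methyl-1H-pyrrol-2-yl gives a number 104 percentage points higher from compound 1 to compound 4 (beyond the scatter). The entering ring differs by one hetero atom at the same heavy-atom count, yet this change moves the read-out where the chain step, no change at the digits printed from compound 1 to compound 3 (within the scatter), did not. Nothing available accounts for the jump.

Open, going by these compounds, is whether 1-ethyl-1H-imidazol-2-yl would hold the level of compound 4. Also open, on these data alone, is whether a thiazol-2-yl or oxazol-2-yl ring would do the same.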